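Working notes: carboxy in place of isopropyl

The compounds below may be only part of what the source reports. "The series", "measured", "known", "first", "only" and "open" are said of these compounds alone.

Values in a functional assay on MT2 cells (Homo sapiens) for cytotoxicity, read by MTT assay; a lower number here means that less compound is tolerated, a higher number that more compound is tolerated:
- compound 1 `CC(C)=CCOc1cc(Nc2nccs2)ccc1Cl`: 26000 nM
- compound 2 `CC(C)=CCOc1cc(Nc2nccs2)ccc1C(C)C`: 31000 nM

Compound 2, at 31000 nM, stands within the scatter of compound 1. Among the compounds with values here, the only measured step is a 1.2-fold higher number from compound 1 to compound 2 (0.08 log units; within the scatter), with isopropyl in place of chloro on an aromatic carbon.

Next comes compound 3 `CC(C)=CCOc1cc(Nc2nccs2)ccc1C(=O)O`, with carboxy in place of isopropyl on an aromatic carbon, ortho to a (3-methylbut-2-en-1-yl)oxy group and para to a (1,3-thiazol-2-yl)amino group: carboxy in place of isopropyl on an aromatic carbon.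

Within the data shown here, only the step of a 1.2-fold higher number from compound 1 to compound 2 (0.08 log units; within the scatter) bears on this place, and it offers weak guidance, since no measured compound carries carboxy. A modest rise in this assay is expected, with little support, and no change beyond the scatter remains possible. The expected change is a 2.3-fold higher number from compound 2 to compound 3 (0.35 log units; beyond the scatter). For compound 3 the estimated value is 70000 nM, with an expected range of 25000 nM to 200000 nM.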

Compound 3, half-maximal cytotoxic concentration: 17000 nM
Compound 3: middle estimate off by 4.1-fold (0.61 log units), on the high side; the measured number lies below the stated range.
By their numbers in this assay, from the lowest: compounds 3, 1 and 2 (each within the scatter of the next).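

In this assay, carboxy on this aromatic carbon, ortho to a (3-methylbut-2-en-1-yl)oxy group and para to a (1,3-thiazol-2-yl)amino group, gives no step beyond the scatter against either earlier group (a 1.8-fold lower number from compound 2 to compound 3 (0.26 log units; within the scatter); a 1.5-fold lower number from compound 1 to compound 3 (0.18 log units; within the scatter)). The earlier compounds shown here compared only chloro and isopropyl, neither with a hydrogen-bond donor or acceptor, whereas carboxy brings one of each and the number still stays within the scatter, so compounds 1, 2 and 3 cannot be ranked by the group at this place. No measurement is available that would account for this result.

On these data alone, whether an amine or a methyl ester at this place would also stay within the scatter remains open. So does the contribution of the (3-methylbut-2-en-1-yl)oxy group, as all three compounds carry it unchanged.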